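Methoxy for fluoro on a short-lived compound

This account rests on a few compounds, and the source may have more. Where it says the series, first, only, none or still open, it means among the compounds named here.

Values from an ADME assay on microsomes from liver (Rattus norvegicus) for metabolic stability, read by LC-MS, using NADPH, at 37 degrees C (on this read-out higher numbers stand for a longer-lived compound and lower numbers for a shorter-lived compound), follow:
- Compound 1 `Cc1oc(-c2ccc(Cl)cc2)nc1CN1CCC(C(=O)NCCCN2C[C@H](C)C[C@H](C)C2)CC1` gives > 0.5 h as a limit of the assay, not a number
- Compound 2 `Cc1oc(-c2ccc(F)cc2)nc1CN1CCC(C(=O)NCCCN2C[C@H](C)C[C@H](C)C2)CC1` gives 0.468 h as its half-life
- Compound 3 `Cc1cccc(F)c1-c1nc(CN2CCC(C(=O)NCCCN3C[C@H](C)C[C@H](C)C3)CC2)c(C)o1` gives 0.0733 h as its half-life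

Compound 3 is the shortest-lived of the three, and its nearest measured neighbour is compound 2 at 0.468 h in this assay for now. Compound 4 `COc1cccc(C)c1-c1nc(CN2CCC(C(=O)NCCCN3C[C@H](C)C[C@H](C)C3)CC2)c(C)o1` differs from compound 3 in a single group, methoxy in place of fluoro on an aromatic carbon with methoxy in place of fluoro on an aromatic carbon. Within the data shown here, two measured steps touch this same aromatic ring, a 6.4-fold lower number from compound 2 to compound 3 (0.81 log units; beyond the scatter) and an at least 6.8-fold lower number from compound 1 to compound 3 (0.83 log units; beyond the scatter) on replacing the whole substituted phenyl group. Both are larger changes than this one, which turns 2-fluoro-6-methylphenyl into 2-methoxy-6-methylphenyl and keeps the methyl. Among the measured compounds shown here, no measured step exchanges fluoro for methoxy, so the direction is open. The expected change is a 1.0-fold lower number from compound 3 to compound 4 (0.02 log units; within the scatter) and no shift beyond the scatter is expected. Compound 4 is estimated at 0.07 h with a range of 0.03 h to 0.16 h as its expected half-life.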

Compound 4, half-life: 0.0767 h
Compound 4: the middle estimate sits 1.1-fold (0.04 log units) below what was measured; low and high end bracket the measured number.
By their numbers in this assay, from the lowest: compounds 3 and 4 (each within the scatter of the next); then compound 2. At a limit, above all of these: compound 1.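

In this assay, methoxy and fluoro are interchangeable at this position, ortho to a large group, with the methyl kept in place (a 1.0-fold higher number from compound 3 to compound 4 (0.02 log units; within the scatter)). The distance from the 4-fluorophenyl compound also holds with the new group (a 6.1-fold lower number from compound 2 to compound 4 (0.79 log units; beyond the scatter)), so the short half-life now goes with two different 2-substituted 6-methylphenyl groups rather than with fluoro alone. Compound 1 carries a limit and not a number, which makes its step only a floor (an at least 6.5-fold lower number from compound 1 to compound 4 (0.81 log units; beyond the scatter)): the limit of > 0.5 h in this assay, at which 1 of the 4 values shown sits.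

The compounds shown leave open what the kept methyl contributes, since it never changes on its own while the other group stays fixed. They also leave open how an amine, a carboxylic acid or a longer chain such as ethoxy would read at this position.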